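This account rests on a few compounds, and the source may have more. Where it says the series, first, only, none or still open, it means among the compounds named here.

Measured compounds:
compound 1, `CCCCNc1nc(N)nc(C)c1CCCCO`, gives 1310 nM in an assay on HEK293 cells for agonist activity at Toll-like receptor 8 (Homo sapiens), read by spectrophotometry; on this read-out lower numbers stand for an effect already at smaller amounts and higher numbers for an effect only at larger amounts of compound.
compound 2, `CCCCNc1nc(N)nc(C)c1CCCn1ccc2ccccc21`, gives 1100 nM in this assay.

Compound 1 stands at the higher of the two numbers, but its nearest neighbour, compound 2, lies within the scatter of it, so the two values show no real difference. The account now follows the step from compound 1 to compound 3, `CCCCNc1nc(N)nc(C)c1CCCN(C)C`, which has not yet been measured in this assay. The change is dimethylamino in place of hydroxymethyl on a saturated chain carbon, three bonds along the chain from an aromatic carbon. Going by the values given here, no measured pair in this set shows a comparable change, so there is no step on which to size the expectation. With only the values of compound 1 and compound 2 to go by, the step is expected to be small, within the scatter or a little toward lower numbers, and a 1.5-fold lower number from compound 1 to compound 3 (0.16 log units; within the scatter) is the step expected. Compound 3 is therefore estimated at 900 nM, with a range from 300 nM to 3000 nM.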

Compound 3, half-maximal effective concentration: 126 nM
Compound 3: middle estimate off by 7.1-fold (0.85 log units), on the high side, and the stated range ends above it.
By their numbers in this assay, from the lowest: compound 3; then compounds 2 and 1 (each within the scatter of the next).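

In this assay, dimethylamino in place of hydroxymethyl on a saturated chain carbon, three bonds along the chain from an aromatic carbon, gives a 10-fold lower number from compound 1 to compound 3 (1.02 log units; beyond the scatter), a step well beyond the scatter. This shows that the number responds strongly to what this chain carries at this place, which compounds 1 and 2, with values within the scatter of each other, gave no sign of. Nothing available explains why this change has so large an effect on the number.

The compounds shown leave open whether the step belongs to dimethylamino specifically or would also appear with a primary amine or a diethylamino group at the same place. They also leave open whether 3-(dimethylamino)propyl is the best length, or whether a shorter or longer chain carrying the same amine would give a lower number still.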